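The source may report more compounds than this note shows. Statements on the series, on what has been measured and on what is new or still open speak of the compounds shown alone.

Measured so far:
compound 1 `Cc1ccc(C2CC(=O)c3ccc(F)cc3O2)cc1`: 160 nM
compound 2 `Cc1ccc2c(c1)OC(c1ccc(F)cc1)CC2=O`: 130 nM

Both were run in an in vitro assay on BTI-TN-5B1-4 cells for inhibition of Amine oxidase [flavin-containing] B (Homo sapiens); a lower number here means a stronger inhibitor, a higher number a weaker inhibitor. Compound 2 gives the lower of the two numbers, but its gap to compound 1 lies within the scatter, so no order between the two is claimed. Compound 3 `O=C1CC(c2ccc(F)cc2)Oc2cc(F)ccc21` is not yet measured. It differs from compound 2 in one place: fluoro in place of methyl on an aromatic carbon. Among the compounds with values here, no measured pair shows this exact change. Within the data shown here, compound 1, the only measured compound carrying fluoro on the fused ring system, gives 160 nM; on that basis no step beyond the scatter is expected in this assay. Compound 3 is expected at 150 nM, range 50 nM to 450 nM, an estimated step of a 1.2-fold higher number from compound 2 to compound 3 (0.06 log units; within the scatter).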

Compound 3, half-maximal inhibitory concentration: 670 nM
The estimate for compound 3 lay 4.5-fold (0.65 log units) below the measured number, and the stated range ends below it.
By their numbers in this assay, from the lowest: compounds 2 and 1 (each within the scatter of the next); then compound 3.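

In this assay fluoro in place of methyl on the fused system of compound 2 gives a 5.2-fold higher number from compound 2 to compound 3 (0.71 log units; beyond the scatter) and the same exchange on the other aromatic ring gives a 4.2-fold higher number from compound 1 to compound 3 (0.62 log units; beyond the scatter) in turn. Methyl and fluoro are therefore not interchangeable at this aromatic carbon, which compound 1 and compound 2 alone could not show: compound 3, the only one of the three without a methyl, gives the highest number. Nothing measured here accounts for the loss.

From the compounds shown here alone, whether the loss follows from losing the methyl or from carrying fluoro on both rings stays open. Going by these compounds, how an ethyl, a methoxy group or an amine at this carbon would compare with methyl also stays open.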